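Replacing the urea link of compound 2 with a plain amide

The source may hold more compounds than are shown below. What is called first, only, known or untested is meant among the compounds shown, and "the series" means these compounds.

Measured so far:
compound 1 `CNC(=O)c1cc(Oc2ccc3nc(NC(=O)Nc4ccc(Cl)cc4Cl)sc3c2)ccn1` 22.3%
compound 2 `CNC(=O)c1cc(Oc2ccc3nc(NC(=O)Nc4ccc(Br)cc4)sc3c2)ccn1` 26.7%
compound 3 `CNC(=O)c1cc(Oc2ccc3nc(NC(=O)Nc4cc(C(F)(F)F)cc(C(F)(F)F)c4)sc3c2)ccn1` 88.1%

In a functional assay on SK-BR-3 cells (Homo sapiens) for inhibition, read by MTT assay, with a stated time of 2 days, tested at 10 uM (a lower number here means less inhibition of growth, a higher number more inhibition of growth at the concentration tested), compound 2 gives 26.7%. It sits close to compound 1, since a number 4.4 percentage points higher from compound 1 to compound 2 (within the scatter), while compound 3 lies far above both. Compound 4 `CNC(=O)c1cc(Oc2ccc3nc(NC(=O)c4ccc(Cl)cc4)sc3c2)ccn1` differs from compound 2 by 4-chlorophenyl in place of (4-bromophenyl)amino on a carbonyl carbon. Among the measured compounds shown here, no measured step touches this part of the molecule: the only recorded step, a number 4.4 percentage points higher from compound 1 to compound 2 (within the scatter), changes the halogen pattern on the aromatic ring and stays within the scatter. The size of the step from compound 2 to compound 4 is therefore uncertain. Compound 4 is expected to stay near compound 2, at 25% (range 5% to 50%), which would be a step of a number 1.7 percentage points lower from compound 2 to compound 4 (within the scatter).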

Compound 4, percent growth inhibition at one concentration: 18.9%
Estimate against measurement, compound 4: 6.1 percentage points above; measured number inside the range.
By their numbers in this assay, from the lowest: compounds 4, 1 and 2 (each within the scatter of the next); then compound 3.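

In this assay, the plain amide link loses the (4-bromophenyl)amino nitrogen and its hydrogen-bond donor, yet the result is a number 7.8 percentage points lower from compound 2 to compound 4 (within the scatter) and likewise a number 3.4 percentage points lower from compound 1 to compound 4 (within the scatter), so at this position the urea nitrogen makes no difference that can be read in this low range. The halogen pattern changes in the same steps, so the two changes cannot be told apart. Nothing measured here explains the result. Going by these compounds, whether a plain amide would keep the high number of compound 3 at 88.1% stays open. So does the effect of a carboxylic acid or a longer chain on the phenyl ring.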